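Piperidine methylation in a quinazoline-benzothiazole amide pair

This account rests on a few compounds, and the source may have more. Where it says the series, first, only, none or still open, it means among the compounds named here.

Measured so far:
compound 1 `COc1cc2c(Nc3nc4ccc(C(=O)Nc5c(C)cc(C)cc5C)cc4s3)ncnc2cc1OCCCN1CCC(C)CC1`: 5900 nM
compound 2 `COc1cc2c(Nc3nc4ccc(C(=O)Nc5c(C)cccc5Cl)cc4s3)ncnc2cc1OCCCN1CCCCC1`: 12500 nM

In a functional assay on K562 cells (Homo sapiens) for cytotoxicity, read by WST assay, with a stated time of 72 h (on this read-out higher numbers stand for weaker inhibition and lower numbers for stronger inhibition), compound 2 gives the higher of the two numbers; compound 1 stands lower, with a gap beyond the scatter. These two differ in more than one place, so the values say only what each compound does on its own.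

Compound 3 `COc1cc2c(Nc3nc4ccc(C(=O)Nc5c(C)cccc5Cl)cc4s3)ncnc2cc1OCCCN1CCC(C)CC1` differs from compound 2 by methyl in place of hydrogen on a saturated ring carbon. Among the measured compounds shown here, no measured pair isolates this change. The step from compound 2 to compound 3 is expected to be small, if anything toward a lower number, with a 1.5-fold lower number from compound 2 to compound 3 (0.17 log units; within the scatter) as the estimate. Compound 3 is estimated at 8500 nM, between 3000 nM and 22000 nM.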

Compound 3, half-maximal inhibitory concentration: 8300 nM
Estimate against measurement, compound 3: 1.0-fold (0.01 log units) above; the measured number falls inside the stated range.
By their numbers in this assay, from the lowest: compounds 1, 3 and 2 (each within the scatter of the next, the first and the last beyond it).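

In this assay, piperidin-1-yl to 4-methylpiperidin-1-yl now stands as an isolated change, and the methyl on this saturated ring carbon gives a step within the scatter (a 1.5-fold lower number from compound 2 to compound 3 (0.18 log units; within the scatter)). The amide-side change, 2-chloro-6-methylphenyl in place of 2,4,6-trimethylphenyl, is also isolated and also stays within the scatter (a 1.4-fold higher number from compound 1 to compound 3 (0.15 log units; within the scatter)). No measurement bears on the reason for either step.

Open, from the compounds shown here alone, is whether a group other than methyl on this ring carbon, such as a hydroxyl or a dimethylamino group, would give a step beyond the scatter. Also open, going by these compounds, is how a morpholine in place of the piperidine would read.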